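Aryl Swap Repeated on a Near-Identical Core

The compounds below may be only part of what the source reports. "The series", "measured", "known", "first", "only" and "open" are said of these compounds alone.

Measured in a functional assay on HCT-116 cells (Homo sapiens) for cytotoxicity, read by MTT assay, with a stated time of 72 h; on this read-out higher numbers stand for weaker inhibition and lower numbers for stronger inhibition:
Compound 1 `Cc1cc(-c2ccccc2)n(/C(N)=N/S(=O)(=O)c2cc(C)c(Cl)cc2SCc2cccc3ccccc23)n1` gives 7000 nM.
Compound 2 `Cc1cc(-c2ccccc2)n(/C(N)=N/S(=O)(=O)c2cc(C)c(Cl)cc2SCc2ccccc2C)n1` gives 42000 nM.
Compound 3 `Cc1cc(S(=O)(=O)/N=C(\N)n2nccc2-c2ccccc2)c(SCc2cccc3ccccc23)cc1Cl` gives 7000 nM.

Compound 3 differs from compound 1 by hydrogen in place of methyl on an aromatic carbon, and the step of no change at the digits printed from compound 1 to compound 3 (within the scatter) lies within the scatter, so the two cores behave alike here. From compound 1 to compound 2 the change is 2-methylphenyl in place of naphthalen-1-yl on a saturated chain carbon bound to a sulfur, and it gave a 6.0-fold higher number from compound 1 to compound 2 (0.78 log units; beyond the scatter). Compound 4 `Cc1cc(S(=O)(=O)/N=C(\N)n2nccc2-c2ccccc2)c(SCc2ccccc2C)cc1Cl` is the unmeasured partner of compound 3 carrying the same change, (2-methylphenyl in place of naphthalen-1-yl on a saturated chain carbon bound to a sulfur), at the same place. Since compound 3 matches compound 1 within no change at the digits printed from compound 1 to compound 3 (within the scatter), the repeated change is expected to move it in the same way, by an expected 6.0-fold higher number from compound 3 to compound 4 (0.78 log units; beyond the scatter) in this assay, resting on the step of a 6.0-fold higher number from compound 1 to compound 2 (0.78 log units; beyond the scatter). Compound 4 is therefore estimated at 42000 nM, with an expected range from 15000 nM to 110000 nM.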

Compound 4, half-maximal inhibitory concentration: 16000 nM
Compound 4: middle estimate off by 2.6-fold (0.42 log units), on the high side; measured number inside the range.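

In this assay 2-methylphenyl in place of naphthalen-1-yl raised the number on the second core as well, giving a 2.3-fold higher number from compound 3 to compound 4 (0.36 log units; beyond the scatter), and the two steps agree within the scatter: the same change on two cores in this assay, a 6.0-fold higher number (0.78 log units; beyond the scatter) from compound 1 to compound 2 and a 2.3-fold higher number (0.36 log units; beyond the scatter) from compound 3 to compound 4, 2.6-fold (0.42 log units) apart, within the scatter of two such steps. Hydrogen in place of methyl on an aromatic carbon gave a 2.6-fold lower number from compound 2 to compound 4 (0.42 log units; beyond the scatter), although compound 1 and compound 3 stand level, and this gap also stays within the scatter: the same change on two cores in this assay, no change at the digits printed (within the scatter) from compound 1 to compound 3 and a 2.6-fold lower number (0.42 log units; beyond the scatter) from compound 2 to compound 4, 2.6-fold (0.42 log units) apart, within the scatter of two such steps. The aryl change therefore carried across in direction and, within the scatter, in size on this one pair of cores, but a single pair establishes no general rule and does not explain the difference between the steps.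

The compounds shown leave open whether this holds for other groups on the saturated chain carbon bound to a sulfur, such as cyclohexyl or a longer chain. They also leave open how an amine or a carboxylic acid in place of that methyl would behave.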